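Changing the Ring on Sulfur in Compound 1

A few compounds are considered here, and "the series" means these few. Any claim that something is new, unique, unknown or untested is made for them only; others in the source may bear on it.

Three compounds were tested in a functional assay on DU-145 cells (Homo sapiens) for inhibition, read by trypan blue exclusion, with a stated time of 96 h; a lower number here means a stronger inhibitor of growth, a higher number a weaker inhibitor of growth:

compound 1, `CCOc1ccc(/C=C(/Sc2ccc(C)cc2)C(=O)c2ccc(Cl)cc2)cc1OC`: 25000 nM
compound 2, `Cc1ccc(/C=C(\C(=O)c2ccc([N+](=O)[O-])cc2)S(=O)(=O)Cc2ccc(Cl)cc2)s1`: 25000 nM
compound 3, `CCOc1ccc(/C=C(/Sc2ccc(C)cc2)C(=O)c2ccc(Br)cc2)cc1OC`: 50000 nM

Compound 1 stands level with compound 2 at the digits shown, and together these two give the lowest numbers of the three. Compound 3 lies furthest from compound 1, yet the step of a 2.0-fold higher number from compound 1 to compound 3 (0.30 log units; within the scatter) stays within the scatter, so the three results are effectively one level of weak growth inhibition.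

Compound 4, `CCOc1ccc(/C=C(/Sc2ccccc2Cl)C(=O)c2ccc(Cl)cc2)cc1OC`, is the next compound to be measured. It differs from compound 1 in a single place: 2-chlorophenyl in place of 4-methylphenyl on a sulfur.

Among the measured compounds shown here, no measured step touches this place. For the measured compounds named here, the one step on record, a 2.0-fold higher number from compound 1 to compound 3 (0.30 log units; within the scatter), concerns the ring on the carbonyl side, not the ring on sulfur, and compound 2 differs from compound 1 in too many places for its value to be read as a single change. The data therefore give no reason to expect a shift beyond the scatter in either direction. The expected step is no change at the digits printed from compound 1 to compound 4 (within the scatter).

Compound 4 is estimated to give 25000 nM in this assay, within a range of 8000 nM to 80000 nM.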

Compound 4, concentration for 50% growth inhibition: 50000 nM
For compound 4 the middle estimate is 2.0-fold (0.30 log units) below the measured one; the range from low to high includes it.
By their numbers in this assay, from the lowest: compounds 1, 2, 3 and 4 (each within the scatter of the next).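

Among the compounds shown here, this is the first measured change to the ring on sulfur, and in this assay it gives a 2.0-fold higher number from compound 1 to compound 4 (0.30 log units; within the scatter). Swapping 4-methylphenyl for 2-chlorophenyl on this sulfur, which exchanges one aromatic carbon ring for another with the same count of heavy atoms, therefore leaves the result at the same weak level of growth inhibition as compound 1. Nothing measured here explains this result or shows how either group acts at this position.

For the compounds shown here, only two aromatic rings on sulfur can be compared here, so it remains open whether a group of a different kind, such as a straight alkyl chain, or a ring carrying an amine or a carboxylic acid, would give a step beyond the scatter. As far as these compounds go, it is also open whether any single change to the core of compound 1 can do so, given that both steps measured from compound 1, at the ring on sulfur and at the ring on the carbonyl side, stay within the scatter.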